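The compounds below may be only part of what the source reports. "The series", "measured", "known", "first", "only" and "open" are said of these compounds alone.

Compound 1 `O=S(=O)(c1ccc(F)c(F)c1)c1cnc2c(F)cccc2c1-c1ccc(Cl)cc1`: 0.28 mL/min
Compound 2 `O=S(=O)(c1ccc(F)c(F)c1)c1cnc2c(F)cccc2c1-c1cccc(F)c1`: 1.28 mL/min
Compound 3 `Cc1ccc(S(=O)(=O)c2cnc3c(F)cccc3c2-c2ccc(Cl)cc2)cc1F`: 2.2 mL/min

All three compounds were tested in an ADME assay on microsomes from liver (Homo sapiens) for metabolic stability, tested at 2.5 uM; a higher number here means faster removal of the compound, a lower number slower removal. Compound 2 differs from compound 1 by 3-fluorophenyl in place of 4-chlorophenyl on an aromatic carbon, and this change gave a 4.6-fold higher number from compound 1 to compound 2 (0.66 log units; beyond the scatter). Compound 3 differs from compound 1 in another part of the molecule, by methyl in place of fluoro on an aromatic carbon, which gave a 7.9-fold higher number from compound 1 to compound 3 (0.90 log units; beyond the scatter). Compound 3 therefore stands highest of the three in this assay, while its gap to compound 2 lies within the scatter.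

Compound 4 `Cc1ccc(S(=O)(=O)c2cnc3c(F)cccc3c2-c2cccc(F)c2)cc1F` has not yet been measured. It differs from compound 3 by 3-fluorophenyl in place of 4-chlorophenyl on an aromatic carbon. The place is described in the same words as for the change from compound 1 to compound 2, so this is the same change, made on the core of compound 3 instead of the core of compound 1; how those two cores differ is given by methyl in place of fluoro on an aromatic carbon. Resting on a 4.6-fold higher number from compound 1 to compound 2 (0.66 log units; beyond the scatter), compound 4 is expected to show a step of about a 3.2-fold higher number from compound 3 to compound 4 (0.50 log units; beyond the scatter), beside that earlier step. Compound 4 is thus estimated at 7 mL/min, with a likely range from 3.5 mL/min to 14 mL/min.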

Compound 4, intrinsic clearance in a liver preparation (reported as CLH), per the amount of preparation that the assay uses: 3.92 mL/min
For compound 4 the middle estimate is 1.8-fold (0.25 log units) above the measured one; the measured number falls inside the stated range.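

In this assay, putting 3-fluorophenyl in place of 4-chlorophenyl gave a 1.8-fold higher number from compound 3 to compound 4 (0.25 log units; within the scatter), and this step does not differ measurably from the same change on the core of compound 1: the same change on two cores in this assay, a 4.6-fold higher number (0.66 log units; beyond the scatter) from compound 1 to compound 2 and a 1.8-fold higher number (0.25 log units; within the scatter) from compound 3 to compound 4, 2.6-fold (0.41 log units) apart, within the scatter of two such steps
Methyl in place of fluoro gave a 3.1-fold higher number from compound 2 to compound 4 (0.49 log units; beyond the scatter), which likewise agrees with its earlier step as far as the scatter allows: the same change on two cores in this assay, a 7.9-fold higher number (0.90 log units; beyond the scatter) from compound 1 to compound 3 and a 3.1-fold higher number (0.49 log units; beyond the scatter) from compound 2 to compound 4, 2.6-fold (0.41 log units) apart, within the scatter of two such steps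
Both changes thus carried over between these two cores with no gap that can be told from the scatter, but these four compounds form a single square, so the two comparisons rest on the same measurements and do not show that either change would keep its size on a third core.

The compounds shown leave open how a different group in either place, such as an amine or a carboxylic acid, would behave in this assay. They also leave open whether a larger set of cores would reveal a real difference between the steps that this small set cannot resolve.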